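Taking one methyl group off compound 1

The compounds below may be only part of what the source reports. "The series", "measured", "known", "first", "only" and "open" are said of these compounds alone.

Among the compounds with values here, in a functional assay on MCF7 cells (Homo sapiens) for antiproliferative activity, read by sulforhodamine B assay, with a stated time of 48 h (on this read-out lower numbers stand for stronger inhibition and higher numbers for weaker inhibition), compound 1 `Cc1ccc(OS(=O)(=O)c2ccc(N3CCN(C)C3=O)cc2)c(C)c1` gives 2500 nM and so stands second highest of the three numbers measured so far. Compound 2 `COc1ccc(OS(=O)(=O)c2ccc(N3CCN(C)C3=O)cc2)cc1OC` gives a higher 12000 nM and compound 3 `COc1cc(OS(=O)(=O)c2ccc(N3CCN(C)C3=O)cc2)cc(OC)c1OC` gives a much lower 120 nM on the same read-out.

Compound 4 `Cc1ccc(OS(=O)(=O)c2ccc(N3CCN(C)C3=O)cc2)cc1` has not been measured yet. It is compound 1 with hydrogen in place of methyl on an aromatic carbon, ortho to a large group and meta to a methyl group, so that 2,4-dimethylphenyl becomes 4-methylphenyl (hydrogen in place of methyl on an aromatic carbon).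

Within the data shown here, only one measured step bears on this change, and only loosely. It is a 100-fold lower number from compound 2 to compound 3 (2.00 log units; beyond the scatter) with methoxy in place of hydrogen on an aromatic carbon. That large step shows that one added group can matter greatly in this pair, and there the added group came with a lower number. Among the measured compounds shown here, it involves methoxy rather than methyl, and no measured pair isolates a methyl group.

Removing a group is therefore expected to move the number upward, though far less. The expected size in this assay is an estimated 2.4-fold higher number from compound 1 to compound 4 (0.38 log units; beyond the scatter) toward weaker inhibition. For compound 4 the estimated value is 6000 nM (expected range 2000 nM to 18000 nM).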

Compound 4, half-maximal inhibitory concentration: > 100000 nM
Compound 4 was reported as a limit; the forecaster's own chance of this, stated with the estimate: 10%; middle value at least 16-fold (1.22 log units) away from the limit.
By their numbers in this assay, from the lowest: compound 3; then compound 1; then compound 2. At a limit, above all of these: compound 4.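

In this assay, a change of a single carbon atom on the aromatic ring, ortho to a large group, produces a large step: an at least 40-fold higher number from compound 1 to compound 4 (1.60 log units; beyond the scatter). Within the data shown here, the only large step known before was a 100-fold lower number from compound 2 to compound 3 (2.00 log units; beyond the scatter), and it involved adding a methoxy group, so no measured pair had isolated a methyl group until this one, which shows that a methyl group at this position is no minor detail. Compound 4 is reported as a limit, > 100000 nM, and not as a number: the limit of > 100000 nM in this assay, at which 1 of the 4 values shown sits.

As far as these compounds go, what stays open is whether the methyl group itself is needed at this position or whether another group would serve equally well there, such as an ethyl group, a chlorine atom or an amine. The compounds shown also leave open whether removing the other methyl group of compound 1, while keeping this one, would produce a step of similar size.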